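Nitrile chain to benzyloxycarbonyl: working notes on compound 3

The source may hold more compounds than are shown below. What is called first, only, known or untested is meant among the compounds shown, and "the series" means these compounds.

In a functional assay on J82 cells (Homo sapiens) for cytotoxicity, read by colorimetric assay and MTT assay (a lower number here means a stronger inhibitor, a higher number a weaker inhibitor), compound 1 (`COc1ccc(-c2cc3c(OC)cc(OC)cc3n(CC#N)c2=O)cc1`) gives 10000 nM. Compound 2 (`COc1ccc(-c2cc3c(OC)cc(OC)cc3n(CCCC#N)c2=O)cc1`) gives 10000 nM, which leaves it level with compound 1, its nearest measured neighbour.

The next change leads to compound 3 (`COc1ccc(-c2cc3c(OC)cc(OC)cc3n(CC(=O)OCc3ccccc3)c2=O)cc1`): benzyloxycarbonyl in place of 2-cyanoethyl on a saturated chain carbon bound to an aromatic nitrogen. In words, this is benzyloxycarbonyl in place of 2-cyanoethyl on a saturated chain carbon bound to an aromatic nitrogen.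

Going by the values given here, only one measured step bears on this change. It is no change at the digits printed from compound 1 to compound 2 (within the scatter), made at the same place, and it stays within the scatter. Among the compounds with values here, it is limited guidance, since it involves only nitrile-bearing chains and no measured compound carries benzyloxycarbonyl at this place.

Within the data shown here, with no change at the digits printed from compound 1 to compound 2 (within the scatter) as the only precedent, no large step is expected in this assay, and any movement is expected to lean slightly towards a lower number. The expected change is a 1.3-fold lower number from compound 2 to compound 3 (0.10 log units; within the scatter). For compound 3 the estimated value is 8000 nM, with an expected range of 2500 nM to 20000 nM.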

Compound 3, half-maximal inhibitory concentration: 10000 nM
The estimate for compound 3 lay 1.3-fold (0.10 log units) below the measured number; low and high end bracket the measured number.
By their numbers in this assay, from the lowest: compounds 1, 2 and 3 (each within the scatter of the next).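

In this assay the exchange of 2-cyanoethyl for benzyloxycarbonyl on a saturated chain carbon bound to an aromatic nitrogen gives no change at the digits printed from compound 2 to compound 3 (within the scatter) and extends the comparison beyond nitrile-bearing chains. The reading against the cyano compound is the same, no change at the digits printed from compound 1 to compound 3 (within the scatter) and so compound 3 at 10000 nM stands level with both earlier compounds. At this place, then, neither losing the nitrile nor bringing in a carbonyl and a six-membered aromatic ring of carbon only separates compound 3 from its neighbours in this assay and this flat reading holds only for these three compounds. No measurement here offers an explanation for this result.

Still open, on these data alone, is whether any group at this place can move the number away from this shared level, for instance an amine, a carboxylic acid or an amide carried on the same saturated chain carbon. As far as these compounds go, all three compounds also share the core of compound 1 with its methoxy groups, so the effect of replacing one of those methoxy groups with a hydroxyl or a halogen remains unknown.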